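The compounds below may be only part of what the source reports. "The series", "measured", "known", "first", "only" and "open" are said of these compounds alone.

Measured compounds in an assay on isolated protein with Bile acid receptor (Homo sapiens) as the target; a lower number here means that less compound is needed, a higher number that more compound is needed for the effect:
- compound 1, `CCOc1cccc(-c2ccc(CN(C(=O)C3CCCCC3)c3cccc(/C=C/C(=O)OC)c3)cc2)c1`: compound 1 gives 147 nM
- compound 2, `COC(=O)/C=C/c1cccc(N(Cc2ccc(-c3cccc(C)c3)cc2)C(=O)C2CCCCC2)c1`: compound 2 gives 109 nM
- compound 3, `COC(=O)/C=C/c1cccc(N(Cc2ccc(-c3c(OC)cccc3OC)cc2)C(=O)C2CCCCC2)c1`: compound 3 gives 77 nM

Compound 3 has the lowest of the three numbers, but its gaps to the others are small: a 1.4-fold lower number from compound 2 to compound 3 (0.15 log units; within the scatter) and a 1.9-fold lower number from compound 1 to compound 3 (0.28 log units; within the scatter) both sit within the scatter, as does a 1.3-fold lower number from compound 1 to compound 2 (0.13 log units; within the scatter). The three measured compounds therefore read as one level in this assay.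

Compound 4, `COC(=O)/C=C/c1cccc(N(Cc2ccc(/C=C/C(=O)NC(C)(C)C)cc2)C(=O)C2CCCCC2)c1`, is the next step from compound 3. Change: 2-((tert-butyl)carbamoyl)ethenyl in place of 2,6-dimethoxyphenyl on an aromatic carbon

All three measured steps only swap substituents on a six-membered aromatic ring of carbon only at this position, and none moved the number beyond the scatter. Going by the values given here, no measured step removes that ring or introduces a 2-((tert-butyl)carbamoyl)ethenyl group, so the change to compound 4 is untested here. The expectation is therefore loose, with a somewhat higher number allowed for compound 4 as the step of a 1.9-fold higher number from compound 3 to compound 4 (0.29 log units; within the scatter).

Compound 4 is estimated at 150 nM in this assay, within 40 nM to 600 nM.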

Compound 4, half-maximal effective concentration: > 1000 nM
Compound 4: only a limit was reported; the forecaster's own chance of this, stated with the estimate: 5%; at least 6.6-fold (0.82 log units) between middle value and limit.
By their numbers in this assay, from the lowest: compounds 3, 2 and 1 (each within the scatter of the next). At a limit, above all of these: compound 4.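

In this assay compound 4 gives only a limit: the limit of > 1000 nM in this assay, at which 1 of the 4 values shown sits. This position is not indifferent to every change: swaps among substituted phenyl groups stayed within the scatter, whereas the new group gives an at least 12-fold higher number from compound 3 to compound 4 (1.11 log units; beyond the scatter) and an at least 9.1-fold higher number from compound 2 to compound 4 (0.96 log units; beyond the scatter) and an at least 6.8-fold higher number from compound 1 to compound 4 (0.83 log units; beyond the scatter). The level shared by compounds 1, 2 and 3 therefore does not extend to 2-((tert-butyl)carbamoyl)ethenyl, which has no ring and carries a hydrogen-bond donor.

Loss of the six-membered aromatic ring and arrival of the amide hydrogen occur in a single step, so the compounds shown cannot say which of the two matters. Going by these compounds, whether a cyclohexyl group or a carboxylic acid on this aromatic carbon stays at the level of compounds 1, 2 and 3 remains open.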